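Clearance notes: methyl to ethyl from compound 1

This account rests on a few compounds, and the source may have more. Where it says the series, first, only, none or still open, it means among the compounds named here.

Measured in an ADME assay on microsomes from liver (Homo sapiens) for metabolic stability, read by LC-MS, using NADPH, with stated times of 10 min and 30 min; on this read-out lower numbers stand for slow clearance and higher numbers for fast clearance:
compound 1 `CCC(=O)N[C@@H]1CCCc2c1cncc2N1C(=O)c2ccc(Cl)cc2[C@@H]1C` gives < 3.5 mL/min/kg (a limit)
compound 2 `CC(=O)N[C@@H]1CCCc2c1cncc2N1C(=O)c2ccc(Cl)cc2[C@@H]1C` gives < 3.5 mL/min/kg (a limit)

Compound 1 stands at a limit of the assay, < 3.5 mL/min/kg, and has no number. Both measured compounds sit at the limit of < 3.5 mL/min/kg in this assay, at which 2 of the 2 values shown sit, for now. For the measured compounds named here, the one measured change, a step that the two limits leave unreadable from compound 1 to compound 2, has no readable size and lies at a different place in the structure. Compound 3 `CCC(=O)N[C@@H]1CCCc2c1cncc2N1C(=O)c2ccc(Cl)cc2[C@@H]1CC` differs from compound 1 by methyl in place of hydrogen on a saturated chain carbon bound to a saturated ring carbon, which reads as methyl to ethyl. No measured step sizes this change, so no shift beyond the scatter is expected in this assay and no direction is favoured. The expected step is a number no lower from compound 1 to compound 3 (the limit leaves the size open) in this reading. The expectation rests on compound 1, whose value < 3.5 mL/min/kg is only a limit. Compound 3 is estimated at 3.5 mL/min/kg, within an expected range from 2 mL/min/kg to 7 mL/min/kg, and a limit may again be all that is reported.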

Compound 3, clearance: < 3.5 mL/min/kg
Compound 3: only a limit was reported (the forecaster's own chance of this, stated with the estimate: 65%); the middle value sits exactly at the limit.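

In this assay, for the compounds shown here, compound 1 and compound 3 both give only a limit, so no step between them can be read: the limit of < 3.5 mL/min/kg in this assay, at which 3 of the 3 values shown sit. The compounds shown leave open whether methyl to ethyl changes clearance at all, and by how much.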